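N-aryl step on the shared core

The source may hold more compounds than are shown below. What is called first, only, known or untested is meant among the compounds shown, and "the series" means these compounds.

Values in a functional assay on A-375 cells (Homo sapiens) for antiproliferative activity, read by MTT assay, with a stated time of 72 h; on this read-out higher numbers stand for weaker inhibition and lower numbers for stronger inhibition:
- compound 1 `COc1ccc(N2C(=O)COc3ccc(-c4cnc(Cl)c(NS(=O)(=O)c5ccc(F)cc5)c4)cc32)cc1`: 32700 nM
- compound 2 `O=C1COc2ccc(-c3cnc(Cl)c(NS(=O)(=O)c4ccc(F)cc4)c3)cc2N1c1ccc(F)cc1`: > 40000 nM (a limit)
- compound 3 `O=C1COc2ccc(-c3cnc(Cl)c(NS(=O)(=O)c4ccc(F)cc4)c3)cc2N1`: > 40000 nM (a limit)

Compound 3 gives only a limit, > 40000 nM, and so has no number of its own. That limit is shared across the set: the limit of > 40000 nM in this assay, at which 2 of the 3 values shown sit.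

Compound 4 `O=C1COc2ccc(-c3cnc(Cl)c(NS(=O)(=O)c4ccc(F)cc4)c3)cc2N1c1ccc(Cl)cc1` brings 4-chlorophenyl in place of hydrogen on an amide-type nitrogen in a ring. The nearest measured steps run the other way, with an aryl group leaving that nitrogen: an at least 1.2-fold higher number from compound 1 to compound 3 (0.08 log units; that floor lies within the scatter), and a step that the two limits leave unreadable from compound 2 to compound 3. Between the two aryl groups, the step is an at least 1.2-fold higher number from compound 1 to compound 2 (0.08 log units; that floor lies within the scatter). None of these shows a change beyond the scatter, so no step beyond the scatter is expected in this assay, and no direction can be assigned. A further report as a limit is quite possible.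

The expected step is an at least 1.0-fold lower number from compound 3 to compound 4 (0.02 log units; that floor lies within the scatter). Compound 4 is estimated at 38000 nM, with an expected range of 18000 nM to 80000 nM.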

Compound 4, half-maximal inhibitory concentration: 30600 nM
Beside the measured number, compound 4's estimate is 1.2-fold (0.09 log units) above it, and the stated range covers the measured number.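

In this assay, 4-chlorophenyl in place of hydrogen on the amide-type nitrogen gives an at least 1.3-fold lower number from compound 3 to compound 4 (0.11 log units; that floor lies within the scatter), and chloro in place of fluoro on that aryl group gives an at least 1.3-fold lower number from compound 2 to compound 4 (0.11 log units; that floor lies within the scatter). Chloro in place of methoxy gives a 1.1-fold lower number from compound 1 to compound 4 (0.03 log units; within the scatter), so two aryl groups on this nitrogen now carry numbers of their own, and these numbers cannot be told apart. Compound 2 and compound 3 are reported only as limits, so the true size of their steps stays unknown: the limit of > 40000 nM in this assay, at which 2 of the 4 values shown sit.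

All readable steps lie within the scatter, which leaves open whether any group on this nitrogen moves the number beyond it. Also open, from the compounds shown here alone, is what an amine or a carboxylic acid on the aryl group, or a longer alkyl chain in its place, would do.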